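A few compounds are considered here, and "the series" means these few. Any claim that something is new, unique, unknown or untested is made for them only; others in the source may bear on it.

Two members of the series have been measured in a functional assay on ACHN cells (Homo sapiens) for antiproliferative activity, read by XTT assay; a higher number here means a weaker inhibitor, a lower number a stronger inhibitor. Compound 1 `O=c1c(Cc2coc3cccc(OCC4CCCCC4)c3c2=O)coc2ccccc12` gives 4230 nM in this assay. Compound 2 `Cc1ccc2c(=O)c(Cc3coc4cccc(OCC5CCCCC5)c4c3=O)coc2c1` gives 2250 nM in this assay. The one step between them, a 1.9-fold lower number from compound 1 to compound 2 (0.27 log units; within the scatter), is within the scatter, so the two numbers cannot be separated on the data shown, and compound 2 stands level with compound 1 rather than apart from it.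

Compound 3 `O=c1c(Cc2coc3cccc(OCC4CCCCC4)c3c2=O)coc2cc(O)ccc12` differs from compound 2 in one place: hydroxy in place of methyl on an aromatic carbon. Within the data shown here, the only measured step that touches this position is a 1.9-fold lower number from compound 1 to compound 2 (0.27 log units; within the scatter), which was within the scatter. Nothing measured speaks to hydroxy at this position, so no step beyond the scatter is assumed for compound 3 in this assay. For compound 3 a step of a 1.3-fold higher number from compound 2 to compound 3 (0.12 log units; within the scatter) is expected in this assay. Compound 3 is thus estimated at 3000 nM in this assay, within a range from 900 nM to 10000 nM.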

Compound 3, half-maximal inhibitory concentration: 2100 nM
Compound 3: the middle estimate sits 1.4-fold (0.15 log units) above what was measured; the range from low to high includes it.
By their numbers in this assay, from the lowest: compounds 3, 2 and 1 (each within the scatter of the next).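

In this assay the exchange of methyl for hydroxy on this aromatic carbon gives a 1.1-fold lower number from compound 2 to compound 3 (0.03 log units; within the scatter) and the exchange of hydrogen for hydroxy gives a 2.0-fold lower number from compound 1 to compound 3 (0.30 log units; within the scatter) so hydrogen, methyl and hydroxy at this position cannot be separated on the numbers shown. The series now includes a group with a hydrogen-bond donor and a hydrogen-bond acceptor on the counts given, where methyl has neither, and the number in this read-out still stays within the scatter of the other two. No measurement is available that would explain this reading.

On these data alone, whether an amine, a carboxylic acid or a longer chain such as ethoxy on this carbon would move the number beyond the scatter remains open. Also open, as far as these compounds go, is whether hydroxy on another aromatic carbon of the ring would behave the same way.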